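The compounds below may be only part of what the source reports. "The series", "measured", "known", "first", "only" and "open" are said of these compounds alone.

Working notes on the series. Compound 1 `Nc1nc(-c2ccccc2)nc2sc(-c3ccccc3)nc12` is the parent. In a functional assay on CHO cells for antagonist activity at adenosine receptor A2b (Homo sapiens), read by cAMP accumulation, with a stated time of 10 min (a higher number here means a weaker inhibitor, a lower number a stronger inhibitor), compound 1 gives > 30000 nM, which is a limit of the assay and not a number. Compound 2 `Nc1nc(-c2ccc(CO)cc2)nc2sc(-c3ccccc3)nc12` gives > 30000 nM in this assay, again a limit. Compound 3 `Nc1nc(-c2cccc(O)c2)nc2sc(-c3ccccc3)nc12` gives > 30000 nM in this assay, also a limit. Accordingly a step that the two limits leave unreadable from compound 1 to compound 2, a step that the two limits leave unreadable from compound 1 to compound 3 and a step that the two limits leave unreadable from compound 2 to compound 3 cannot be sized; the only evidence is the limit of > 30000 nM in this assay, at which 3 of the 3 values shown sit. Compound 4 `Nc1nc(-c2ccco2)nc2sc(-c3ccccc3)nc12` carries furan-2-yl in place of phenyl on an aromatic carbon. For the measured compounds named here, no measured step bears readably on this change, so no direction can be drawn from the measured compounds. Compound 4 is estimated at 30000 nM, range 8000 nM to 100000 nM, and the expected step of a number no higher from compound 1 to compound 4 (the limit leaves the size open) rests only on the shared limit.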

Compound 4, half-maximal inhibitory concentration: > 30000 nM
Compound 4 was reported as a limit (the forecaster's own chance of this, stated with the estimate: 75%); the middle value lies on the limit itself.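

Compound 4 gives > 30000 nM in this assay, again a limit and not a number, so the steps linking compound 4 with compound 1, compound 2 and compound 3 cannot be read; the only evidence is: the limit of > 30000 nM in this assay, at which 4 of the 4 values shown sit.

The compounds shown leave open how far any of these compounds lies from another, and whether any group at this place gives a readable value.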